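Formyl in place of methoxy: an expected shift

The source may report more compounds than this note shows. Statements on the series, on what has been measured and on what is new or still open speak of the compounds shown alone.

Measured compounds:
compound 1 `c1ccc(-c2cn3ccnc3c(-c3ccc4ncn(C5CCCCC5)c4c3)n2)cc1` — 51.6%
compound 2 `COc1ccc(-c2cn3ccnc3c(-c3ccc4ncn(C5CCCCC5)c4c3)n2)cc1` — 78.8%

In a functional assay on HCT-15 cells (Homo sapiens) for inhibition, read by sulforhodamine B assay, with a stated time of 48 h, tested at 10 uM (on this read-out higher numbers stand for more inhibition at the one concentration tested (going by the name of the read-out) and lower numbers for less inhibition), compound 2 gives 78.8%, the higher of the two numbers. Compound 1 gives 51.6% in this assay. Among the compounds with values here, the one step known, a number 27.2 percentage points higher from compound 1 to compound 2 (beyond the scatter), shows that the methoxy group carries a gain beyond the scatter. Compound 3 `O=Cc1ccc(-c2cn3ccnc3c(-c3ccc4ncn(C5CCCCC5)c4c3)n2)cc1` differs from compound 2 by formyl in place of methoxy on an aromatic carbon. Within the data shown here, no measured step tells how formyl compares with methoxy, so the expectation for compound 3 is a moderate fall of a number 18.8 percentage points lower from compound 2 to compound 3 (beyond the scatter), landing partway back toward compound 1. Compound 3 is estimated at 60%, within 38% to 82%.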

Compound 3, a percentage reported as inhibition, at one concentration (the size of the read-out at that concentration, not a potency): 49.1%
Beside the measured number, compound 3's estimate is 10.9 percentage points above it; measured number inside the range.
By their numbers in this assay, from the lowest: compounds 3 and 1 (each within the scatter of the next); then compound 2.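

In this assay, the gain seen with methoxy on this aromatic carbon, para to a large group, does not carry over to formyl (a number 29.7 percentage points lower from compound 2 to compound 3 (beyond the scatter)). Formyl in place of hydrogen leaves the number within the scatter (a number 2.5 percentage points lower from compound 1 to compound 3 (within the scatter)), so at this place methoxy stands apart from both hydrogen and formyl. Nothing measured here bears on what separates methoxy from formyl. As far as these compounds go, whether an amine or a carboxylic acid at this place would behave like methoxy or like formyl stays open, as does whether a longer chain on the oxygen of methoxy would keep the gain.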